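The source may report more compounds than this note shows. Statements on the series, on what has been measured and on what is new or still open speak of the compounds shown alone.

Compound 1, `CCCCCCCCC/C=C\CCCCCCC(=O)N[C@H]1[C@H](OC(=O)CCC(=O)O)O[C@H](CO)[C@@H](OC(=O)CCC(=O)O)[C@@H]1OC(=O)CCCCCCCCCCCCC`: 2700 nM
Compound 2, `CCCCC/C=C\C/C=C\CCCCCCC(=O)N[C@H]1[C@H](OC(=O)CCC(=O)O)O[C@H](CO)[C@@H](OC(=O)CCC(=O)O)[C@@H]1OC(=O)CCCCCCCCCCCCC`: 6610 nM

For the measured compounds named here, in an assay on HEK-Blue hTLR4 cells for inhibition of Toll-like receptor 4 (Homo sapiens), with stated times of 15 min and 16 h (a higher number here means a weaker inhibitor, a lower number a stronger inhibitor), compound 2 gives the higher of the two numbers, so it is the weaker inhibitor of the pair, and the only measured step that leads to it is a 2.4-fold higher number from compound 1 to compound 2 (0.39 log units; beyond the scatter), which came from adding a second double bond to the amide chain.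

Compound 3, `CCCCC/C=C\C/C=C\CCCCCCC(=O)N[C@H]1[C@H](OC(=O)CCC(=O)O)O[C@H](CO)[C@@H](OC(=O)CCC(=O)O)[C@@H]1OC(=O)CCCCCC/C=C\C/C=C\CCCCC`, keeps that amide chain and changes the ester side instead: deca-1,4-dien-1-yl in place of heptyl on a saturated chain carbon, six bonds along the chain from a carbonyl carbon. The entering group brings two double bonds and a longer chain where a saturated heptyl stood. Going by the values given here, the one step measured so far, a 2.4-fold higher number from compound 1 to compound 2 (0.39 log units; beyond the scatter), points to added unsaturation weakening inhibition modestly, though it sat on a different chain. On that basis compound 3 is expected to be a somewhat weaker inhibitor, roughly a 1.7-fold higher number from compound 2 to compound 3 (0.22 log units; within the scatter). Compound 3 is therefore estimated at 11000 nM, with a range from 4500 nM to 27000 nM.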

Compound 3, half-maximal inhibitory concentration: 4350 nM
Compound 3: the middle estimate sits 2.5-fold (0.40 log units) above what was measured, and the stated range ends above it.
By their numbers in this assay, from the lowest: compounds 1, 3 and 2 (each within the scatter of the next, the first and the last beyond it).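

In this assay, the ester chain accepts deca-1,4-dien-1-yl in place of heptyl, six bonds along the chain from a carbonyl carbon, with a 1.5-fold lower number from compound 2 to compound 3 (0.18 log units; within the scatter), so this exchange does not separate the two compounds. The added double bonds and extra length at this place therefore do not repeat what the extra double bond on the amide chain showed, a 2.4-fold higher number from compound 1 to compound 2 (0.39 log units; beyond the scatter). No measurement here bears on why the two chains respond differently.

From the compounds shown here alone, the added length and the double bonds enter together, so their separate contributions remain open, and a longer saturated chain at this place would be needed to tell them apart. Also open, going by these compounds, is whether this place accepts anything other than a plain hydrocarbon chain, such as a chain carrying an amine.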